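The source may report more compounds than this note shows. Statements on the series, on what has been measured and on what is new or still open speak of the compounds shown alone.

In a functional assay on THP-1 cells (Homo sapiens) for inhibition, read by sulforhodamine B assay, with a stated time of 48 h, tested at 50 uM (on this read-out higher numbers stand for more inhibition of growth at the one concentration tested and lower numbers for less inhibition of growth), compound 1 `COc1cc(/C=C/C(=O)/C=C/c2cccc3ccccc23)ccc1OCc1cn(CCCOc2cc(=O)oc3ccccc23)nn1` gives 71%, compound 2 `COc1ccc(/C=C/C(=O)/C=C/c2ccc(OCc3cn(CCCOc4cc(=O)oc5ccccc45)nn3)c(OC)c2)cc1` gives 56% and compound 3 `COc1cc(/C=C/C(=O)/C=C/c2ccccc2)ccc1OCc1cn(CCCOc2cc(=O)oc3ccccc23)nn1` gives 48%. Compound 3 therefore sits well under compound 1 and within the scatter of compound 2. Compound 4 `COc1cc(/C=C/C(=O)/C=C/c2cc(OC)c(OC)c(OC)c2)ccc1OCc1cn(CCCOc2cc(=O)oc3ccccc23)nn1` differs from compound 3 in one group: 3,4,5-trimethoxyphenyl in place of phenyl on a double-bonded chain carbon bound to a double-bonded chain carbon. Changing the group at this same place earlier gave a number 15 percentage points lower from compound 1 to compound 2 (beyond the scatter) and a number 23 percentage points lower from compound 1 to compound 3 (beyond the scatter), both modest. Putting hydrogen in place of a single methoxy gave a number 8 percentage points lower from compound 2 to compound 3 (within the scatter), which is within the scatter. Neither comparison tests three methoxy groups together, so only a small rise is expected. The expected step is a number 7 percentage points higher from compound 3 to compound 4 (within the scatter), which may not clear the scatter. For compound 4 the estimated value is 55%, with an expected range of 40% to 72%.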

Compound 4, percent growth inhibition at one concentration: 79%
Compound 4: middle estimate off by 24 percentage points, on the low side, and the stated range ends below it.
By their numbers in this assay, from the lowest: compounds 3 and 2 (each within the scatter of the next); then compounds 1 and 4 (each within the scatter of the next).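

In this assay, a single methoxy on the phenyl ring moved the number by no more than the scatter, yet 3,4,5-trimethoxyphenyl at this place gives a number 31 percentage points higher from compound 3 to compound 4 (beyond the scatter) and a number 23 percentage points higher from compound 2 to compound 4 (beyond the scatter) as well. With a number 8 percentage points higher from compound 1 to compound 4 (within the scatter) in comparison with naphthalen-1-yl, this substituted phenyl ring stands level with that larger aromatic group. The data available offer no explanation for the rise.

From the compounds shown here alone, whether all three methoxy groups are needed remains open. So does how an amine or a carboxylic acid on the ring would fare at this place.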